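Adding a methyl to the chain carbon of compound 1

This account rests on a few compounds, and the source may have more. Where it says the series, first, only, none or still open, it means among the compounds named here.

Compound 1 `COc1ccc(Cn2nnc3c(C(N)=O)ncn3c2=O)cc1` is the reference point in a functional assay on U-373MG ATCC cells for inhibition, with U373 MG (Homo sapiens) as the target, read by MTT assay, with a stated time of 7 days; a lower number here means a stronger inhibitor of growth, a higher number a weaker inhibitor of growth. In this assay compound 1 gives > 50000 nM, which is a limit and not a number. Compound 2 `COc1ccc(Cn2nnc3c(C(N)=O)ncn3c2=O)c(OC)c1` gives > 50000 nM, also a limit. Compound 1 therefore has no numerical position in the series, only (the limit of > 50000 nM in this assay, at which 2 of the 2 values shown sit).

Compound 3 `COc1ccc([C@@H](C)n2nnc3c(C(N)=O)ncn3c2=O)cc1` carries a single change: methyl in place of hydrogen on a saturated chain carbon bound to an aromatic carbon and an aromatic nitrogen. Among the measured compounds shown here, the one measured step is a step that the two limits leave unreadable from compound 1 to compound 2. That step concerns an aromatic carbon rather than the saturated chain carbon, and it gives no size or direction to carry over. For the measured compounds named here, no measured step touches the chain carbon. The working expectation is therefore no step beyond the scatter, in neither direction, and another report of only a limit is the likeliest outcome. The expected step is a number no higher from compound 1 to compound 3 (the limit leaves the size open), an estimate with no firm direction. For compound 3 the estimated value in this assay is 50000 nM, with an expected range from 25000 nM to 100000 nM.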

Compound 3, concentration for 50% growth inhibition: > 50000 nM
Compound 3: a limit, no number; the forecaster's own chance of this, stated with the estimate: 75%; the middle value lies on the limit itself.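

No step can be read between compound 1 and compound 3, and the series stays without a numerical position in this assay: the limit of > 50000 nM in this assay, at which 3 of the 3 values shown sit.

The compounds shown leave open whether any change to the shared core, on the aromatic carbon or on the saturated chain carbon, can give a numerical value in this assay, and in which direction methyl in place of hydrogen would then move it.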